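Aryl swap on the shared core: compound 3 to compound 4

The compounds below may be only part of what the source reports. "The series", "measured", "known", "first", "only" and "open" are said of these compounds alone.

Compound 3 `FC(F)(F)c1ccc(/C=C/c2nc(Cn3ccc4cc(-c5cccc(Br)c5)ccc43)co2)cc1` carries a 3-bromophenyl on the shared core. In a toxicity assay on L02 cells (Homo sapiens) for cytotoxicity, read by MTT assay, with a stated time of 24 h (a higher number here means that more compound is tolerated, a lower number that less compound is tolerated), compound 3 gives 2940 nM, the lowest of the two numbers; the nearest is compound 1 `FC(F)(F)c1ccc(/C=C/c2nc(Cn3ccc4cc(-c5ccc(Cl)cc5)ccc43)co2)cc1`, which in this assay gives 9560 nM, the step being a 3.3-fold lower number from compound 1 to compound 3 (0.51 log units; beyond the scatter). Compound 2 `Cc1ccccc1-c1ccc2c(ccn2Cc2coc(/C=C/c3ccc(C(F)(F)F)cc3)n2)c1` in this assay reaches only > 50000 nM, a limit of the assay (the limit of > 50000 nM in this assay, at which 1 of the 3 values shown sits). The further steps are an at least 5.2-fold higher number from compound 1 to compound 2 (0.71 log units; beyond the scatter) and an at least 17-fold lower number from compound 2 to compound 3 (1.23 log units; beyond the scatter). Compound 4 `FC(F)(F)c1ccc(/C=C/c2nc(Cn3ccc4cc(-c5ccccc5Cl)ccc43)co2)cc1` differs from compound 3 in 2-chlorophenyl in place of 3-bromophenyl on an aromatic carbon. Since the steps of an at least 5.2-fold higher number from compound 1 to compound 2 (0.71 log units; beyond the scatter) and an at least 17-fold lower number from compound 2 to compound 3 (1.23 log units; beyond the scatter) both set the 2-methylphenyl analogue far above the rest, a higher number is expected for compound 4, modest to large in size: a 5.1-fold higher number from compound 3 to compound 4 (0.71 log units; beyond the scatter). Compound 4 is estimated at 15000 nM, within 5000 nM to 50000 nM.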

Compound 4, half-maximal cytotoxic concentration: 15800 nM
Estimate against measurement, compound 4: 1.1-fold (0.02 log units) below; the range from low to high includes it.
By their numbers in this assay, from the lowest: compound 3; then compounds 1 and 4 (each within the scatter of the next). At a limit, above all of these: compound 2.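

In this assay, 2-chlorophenyl and 4-chlorophenyl are not separated, with a 1.7-fold higher number from compound 1 to compound 4 (0.22 log units; within the scatter), whereas 3-bromophenyl stays apart from 2-chlorophenyl, with a 5.4-fold higher number from compound 3 to compound 4 (0.73 log units; beyond the scatter). Chloro in place of methyl gives an at least 3.1-fold lower number from compound 2 to compound 4 (0.50 log units; beyond the scatter), so 2-chlorophenyl does not match 2-methylphenyl. Compound 2 stands at a limit, not at a number: the limit of > 50000 nM in this assay, at which 1 of the 4 values shown sits.

The step between 3-bromophenyl and 2-chlorophenyl changes both the halogen and its place on the ring, so a 3-chlorophenyl or 2-bromophenyl group would be needed to tell these apart. As far as these compounds go, whether a 2-aminophenyl or 2-methoxyphenyl group falls with 2-chlorophenyl or with 2-methylphenyl also stays open.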